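From Compound 1 to Compound 4 in Vero Cell Toxicity

This account rests on a few compounds, and the source may have more. Where it says the series, first, only, none or still open, it means among the compounds named here.

Compound 1 `COc1ccc2[nH]c(C(=O)N3CC(=O)N(Cc4ccccc4)[C@@H](COc4ccccc4)C3)cc2c1` was tested in an ADME assay on Vero cells (Chlorocebus sabaeus) for cytotoxicity, with a stated time of 7 days (on this read-out higher numbers stand for lower toxicity in this test and lower numbers for higher toxicity in this test), where compound 1 gives > 10000 nM, a limit of the test rather than a number. Compound 1 therefore sits at the limit of > 10000 nM in this assay, at which 1 of the 3 values shown sits, so only a bound is known for it. Compound 3 `COc1ccc2[nH]c(C(=O)N3CC(=O)N(Cc4ccccc4)[C@@H](N4CCC(Cc5ccccc5)CC4)C3)cc2c1` also returns a limit: in this assay compound 3 gives > 30000 nM. Within the data shown here, compound 2 `Cc1ccc2[nH]c(C(=O)N3CC(=O)N(Cc4ccccc4)[C@@H](CN4CCC5(CCC5)CC4)C3)cc2c1` is the one measured compound with a number, giving 7800 nM in this assay. Compound 4 `COc1ccc2[nH]c(C(=O)N3CC(=O)N(Cc4ccccc4)[C@@H](CN4CC5(CCC5)C4)C3)cc2c1` has not yet been measured in this assay. It differs from compound 1 as follows: a group of 7 heavy atoms (6 carbon, 1 nitrogen; one four-membered non-aromatic ring of carbon only, one four-membered non-aromatic ring with 1 hetero atom) in place of a group of 7 heavy atoms (6 carbon, 1 oxygen; one six-membered aromatic ring of carbon only), on a saturated chain carbon bound to a saturated ring carbon. Among the measured compounds shown here, no step between two measured compounds is available here, so the expectation rests on the measured values alone. The step of an at least 1.1-fold lower number from compound 1 to compound 4 (0.04 log units; that floor lies within the scatter) is expected to be small, at most around the usual scatter, and if anything toward a somewhat lower number. Compound 4 is estimated at 9000 nM, within 4000 nM to 20000 nM, with a fair chance that the test returns only a limit again.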

Compound 4, half-maximal cytotoxic concentration: 52700 nM
Estimate against measurement, compound 4: 5.9-fold (0.77 log units) below, and the stated range ends below it.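

In this assay, among these compounds, compound 1 gives > 10000 nM and this is a limit of the test, so no step from compound 1 to compound 4 can be read. The compounds shown leave open how large the change from the phenoxy group to the entering group is in this assay and in which direction it runs.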